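From chloromethyl to phenyl on the shared core

This account rests on a few compounds, and the source may have more. Where it says the series, first, only, none or still open, it means among the compounds named here.

In an ADME assay on J774 cells (Mus musculus) for cytotoxicity, read by resazurin assay, with a stated time of 72 h (a lower number here means that less compound is tolerated, a higher number that more compound is tolerated), compound 1 `C/C(=N\Nc1nc(C)cs1)c1ccc(Cl)c(Cl)c1` gives 33700 nM. Compound 2 `C/C(=N\Nc1nc(CCl)cs1)c1ccc(Cl)c(Cl)c1` stands at the limit of > 50000 nM in this assay, at which 1 of the 2 values shown sits, so its > 50000 nM is a limit and not a number. Compound 3 `C/C(=N\Nc1nc(-c2ccccc2)cs1)c1ccc(Cl)c(Cl)c1` alters the group that was changed in the previous step: phenyl in place of chloromethyl on an aromatic carbon. Among the measured compounds shown here, only one measured step bears on this change: an at least 1.4-fold higher number from compound 1 to compound 2 (0.17 log units; that floor lies within the scatter). That step is only a floor and lies within the scatter, and it concerns a much smaller swap, so it is a weak guide. No clear shift is therefore expected in this assay, although a lower number remains possible. The expected change is an at least 1.6-fold lower number from compound 2 to compound 3 (0.22 log units; that floor lies within the scatter), which would not go beyond the scatter. For compound 3 the estimated value is 30000 nM, with an expected range from 12000 nM to 50000 nM.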

Compound 3, half-maximal cytotoxic concentration: > 50000 nM
Compound 3: no number, only a limit; the forecaster's own chance of this, stated with the estimate: 35%; at least 1.6-fold (0.22 log units) between middle value and limit.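

In this assay compound 3 gives > 50000 nM, which is a limit and not a number, so phenyl on this aromatic carbon, next to the ring nitrogen, brings no drop to a measurable value. Phenyl in place of methyl gives an at least 1.4-fold higher number from compound 1 to compound 3 (0.17 log units; that floor lies within the scatter), so the change is known only as a floor, and that floor does not go beyond the scatter. The step from compound 2 to compound 3 cannot be read, and the two compounds now share one limit: the limit of > 50000 nM in this assay, at which 2 of the 3 values shown sit.

On these data alone, how far the numbers of compound 2 and compound 3 truly lie from that of compound 1 stays open, as does any order between chloromethyl and phenyl. Also open, as far as these compounds go, is how an amine or a carboxylic acid on this same aromatic carbon would fare.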